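This account rests on a few compounds, and the source may have more. Where it says the series, first, only, none or still open, it means among the compounds named here.

Measured compounds:
- compound 1, `C=C1C[C@]23C[C@@]1(O)CC[C@H]2c1ccc(O)c(C)c1[C@@H]3Cn1cc(-c2ccc(C(F)(F)F)cc2)nn1`: 12400 nM
- compound 2, `C=C1C[C@]23C[C@@]1(O)CC[C@H]2c1cc(Br)c(O)c(C)c1[C@@H]3Cn1cc(-c2ccc(F)cc2)nn1`: 19200 nM
- compound 3, `C=C1C[C@]23C[C@@]1(O)CC[C@H]2c1cc(Br)c(O)c(C)c1[C@@H]3Cn1cc(-c2ccccn2)nn1`: > 20000 nM

Compound 1, compound 2 and compound 3 share one core and differ only in the bromine on the phenol ring and in the aryl group on the triazole. In a functional assay on MCF7 cells (Homo sapiens) for cytotoxicity, read by MTT assay, with a stated time of 4 days (a lower number here means a stronger inhibitor, a higher number a weaker inhibitor), compound 1 gives 12400 nM. Compound 2, which carries the bromine and a 4-fluorophenyl group, gives 19200 nM. For compound 3 the value > 20000 nM is a limit of the assay, not a number, as described by the limit of > 20000 nM in this assay, at which 1 of the 3 values shown sits. Compound 3 therefore stands at the weak end of the numbers shown, and the step of an at least 1.0-fold higher number from compound 2 to compound 3 (0.01 log units; that floor lies within the scatter) is only a floor that lies within the scatter.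

Compound 4, `C=C1C[C@]23C[C@@]1(O)CC[C@H]2c1cc(Br)c(O)c(C)c1[C@@H]3Cn1cc(-c2ccc(C(F)(F)F)cc2)nn1`, has not been measured. It arises from compound 3 through (4-(trifluoromethyl)phenyl in place of pyridin-2-yl on an aromatic carbon). Among the compounds with values here, the only measured step that bears on this change, the one from compound 2 to compound 3, replaced a 4-fluorophenyl group by pyridin-2-yl and moved the number from a measured value to a limit; the return toward an aryl group of carbon only is expected to bring compound 4 back to a measured number. Compound 1 carries the same 4-(trifluoromethyl)phenyl group without the bromine and gives a value of 12400 nM, which supports an expected step of an at least 1.2-fold lower number from compound 3 to compound 4 (0.09 log units; that floor lies within the scatter) for compound 4. Compound 4 is accordingly estimated at 16000 nM, with a range from 8000 nM to 30000 nM.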

Compound 4, half-maximal inhibitory concentration: 8100 nM
Beside the measured number, compound 4's estimate is 2.0-fold (0.30 log units) above it; measured number inside the range.
By their numbers in this assay, from the lowest: compounds 4, 1 and 2 (each within the scatter of the next, the first and the last beyond it). At a limit, above all of these: compound 3.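

In this assay, with the bromine held fixed, the group on the aromatic carbon of the five-membered aromatic ring with 3 nitrogen now gives steps beyond the scatter: 4-(trifluoromethyl)phenyl in place of pyridin-2-yl gives an at least 2.4-fold lower number from compound 3 to compound 4 (0.39 log units; beyond the scatter) and trifluoromethyl in place of fluoro gives a 2.4-fold lower number from compound 2 to compound 4 (0.37 log units; beyond the scatter). The first of these steps is only a floor, and compound 3 stands at a limit of the assay, not a number: the limit of > 20000 nM in this assay, at which 1 of the 4 values shown sits. Bromo in place of hydrogen on an aromatic carbon, seen here for the first time as a single change, gives a 1.5-fold lower number from compound 1 to compound 4 (0.18 log units; within the scatter) and so cannot be told apart from repeated measurement with the 4-(trifluoromethyl)phenyl group in place.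

The compounds shown leave open how an amine or a carboxylic acid in place of trifluoromethyl would read in this assay. They also leave open whether bromo in place of hydrogen stays within the scatter when the five-membered aromatic ring carries an aryl group other than 4-(trifluoromethyl)phenyl.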